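The source may report more compounds than this note shows. Statements on the series, on what has been measured and on what is new or still open speak of the compounds shown alone.

Working notes on the series. Compound 1 `CC(C)C[C@@H]1NC(=O)[C@H](Cc2cnc[nH]2)NC1=O` carries 1H-imidazol-5-yl on a saturated chain carbon bound to a saturated ring carbon; compound 2 `CC(C)C[C@@H]1NC(=O)[C@H](CC(N)=O)NC1=O` carries carbamoyl in the same place. In a functional assay, tested at 2.5 mM (on this read-out higher numbers stand for more inhibition at the one concentration tested (going by the name of the read-out) and lower numbers for less inhibition), compound 1 gives 83.9%, while compound 2 gives 96%. Going by the values given here, the single measured step, a number 12.1 percentage points higher from compound 1 to compound 2 (beyond the scatter), is the whole of what is known about change at this position. On the numbers shown, compound 2 stands highest of the two, its nearest neighbour compound 1 being lower by a gap beyond the scatter.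

Compound 3 `CC(C)C[C@@H]1NC(=O)[C@H](CCC(N)=O)NC1=O` is the next member, differing from compound 2 by carbamoylmethyl in place of carbamoyl on a saturated chain carbon bound to a saturated ring carbon. The measured step concerns a swap of one group for another at this place and not a lengthening of the chain by one carbon, so it bears only loosely here. Compound 2 already sits close to the top of the read-out, leaving little room upward. The number for compound 3 is estimated at 88%, within a range of 70% to 98%. The expected step is therefore a number 8 percentage points lower from compound 2 to compound 3 (within the scatter), most likely within the scatter or a small fall.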

Compound 3, a percentage reported as inhibition, at one concentration (the size of the read-out at that concentration, not a potency): 19%
For compound 3 the middle estimate is 69 percentage points above the measured one; measured number outside the range, below it.
By their numbers in this assay, from the lowest: compound 3; then compound 1; then compound 2.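

In this assay, going by these compounds alone, the position proves far more sensitive than the one earlier step suggested: one added chain carbon gives a number 77 percentage points lower from compound 2 to compound 3 (beyond the scatter), against the modest a number 12.1 percentage points higher from compound 1 to compound 2 (beyond the scatter) seen between the first two groups. Carbamoyl and carbamoylmethyl have the same counted hydrogen-bond donors, hydrogen-bond acceptors and net charge, so those counts do not separate the two compounds, while the replacement of 1H-imidazol-5-yl by carbamoylmethyl also brings a number 64.9 percentage points lower from compound 1 to compound 3 (beyond the scatter), and carbamoylmethyl is thus the only one of the three groups linked to a low number. Nothing available on these compounds gives a measured reason for this fall.

Within the data shown here, with only three compounds, it stays open whether the loss comes from the added carbon or from where the amide ends up relative to the shared core. A carboxylic acid or a primary amine in place of the amide on the carbamoylmethyl chain, and a longer chain ending in carbamoyl, would show whether the low number belongs to the chain itself or to the chain together with its end group.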